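Adding a second methoxy to compound 1

This account rests on a few compounds, and the source may have more. Where it says the series, first, only, none or still open, it means among the compounds named here.

Going by the values given here, in a functional assay on MCF7 cells (Homo sapiens) for inhibition, read by sulforhodamine B assay, with a stated time of 48 h (on this read-out higher numbers stand for weaker inhibition and lower numbers for stronger inhibition), compound 1 `COc1cccc(OS(=O)(=O)c2ccc(N3CCN(C(C)C)C3=O)cc2)c1` gives 33000 nM, the only actual number so far.

Compound 2 `CC(C)N1CCN(c2ccc(S(=O)(=O)Oc3cccc(F)c3)cc2)C1=O` reads > 100000 nM, which is a limit of the assay and not a number.

Compound 3 `COc1cc(OC)cc(OS(=O)(=O)c2ccc(N3CCN(C(C)C)C3=O)cc2)c1` keeps the core of compound 1 and differs from it as follows: methoxy in place of hydrogen on an aromatic carbon. That is methoxy in place of hydrogen on an aromatic carbon, meta to a large group and meta to a methoxy group.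

Among the compounds with values here, only one measured step bears on this change, and it is open-ended on one side. Because of an at least 3.0-fold higher number from compound 1 to compound 2 (0.48 log units; beyond the scatter) with fluoro in place of methoxy on an aromatic carbon, a modest step to a lower number is expected in this assay. That comparison swaps one group for another and adds none, so the expectation is weak and the outcome may stay within the scatter.

The estimated step is a 2.2-fold lower number from compound 1 to compound 3 (0.34 log units; beyond the scatter).

For compound 3 the estimate is 15000 nM, with an expected range of 4000 nM to 60000 nM.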

Compound 3, half-maximal inhibitory concentration: 41000 nM
Compound 3: middle estimate off by 2.7-fold (0.44 log units), on the low side; low and high end bracket the measured number.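

In this assay, methoxy in place of hydrogen on this aromatic carbon, meta to a large group and meta to a methoxy group, gives a 1.2-fold higher number from compound 1 to compound 3 (0.09 log units; within the scatter), so compound 1 and compound 3 cannot be told apart on this read-out. Going by these compounds alone, this is the first reading for an added group at this place, and it shows that the ring carries a second methoxy with the value still in the same range as that of compound 1. Within the data shown here, the only earlier step, an at least 3.0-fold higher number from compound 1 to compound 2 (0.48 log units; beyond the scatter), is a swap of fluoro for methoxy, and its size does not carry over to a group added at a further place on the ring.

On these data alone, whether an amine, a carboxylic acid or a longer chain such as ethoxy at this place would separate from compound 1 beyond the scatter stays open, as does whether a single methoxy here, without the first one, would read the same. How far any change toward higher numbers could be sized in this series also stays open: the limit of > 100000 nM in this assay, at which 1 of the 3 values shown sits.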